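From Chloro to Ethoxy: Expected Cytotoxicity of Compound 4

The source may hold more compounds than are shown below. What is called first, only, known or untested is meant among the compounds shown, and "the series" means these compounds.

Compound 1 `CCCCCCNc1nc(SCc2ccc(C(F)(F)F)cc2)nc2ccccc12` gives 19000 nM in a functional assay on PC-3 cells (Homo sapiens) for cytotoxicity, read by MTT assay, with a stated time of 72 h; a higher number here means a weaker inhibitor, a lower number a stronger inhibitor.
Compound 2 `FC(F)(F)c1ccc(CSc2nc(N3CCCCC3)c3ccccc3n2)cc1` gives 25500 nM in this assay.
Compound 3 `FC(F)(F)c1ccc(CSc2nc(Nc3ccc(Cl)cc3)c3ccccc3n2)cc1` gives 7110 nM in this assay.

Compound 3 shows the lowest number of the three. Its distance from compound 1 is a 2.7-fold lower number from compound 1 to compound 3 (0.43 log units; beyond the scatter), and from compound 2 it is a 3.6-fold lower number from compound 2 to compound 3 (0.55 log units; beyond the scatter); both steps lie beyond the scatter. The step of a 1.3-fold higher number from compound 1 to compound 2 (0.13 log units; within the scatter) lies within the scatter, so compound 1 and compound 2 cannot be ordered against each other.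

Compound 4 `CCOc1ccc(Nc2nc(SCc3ccc(C(F)(F)F)cc3)nc3ccccc23)cc1` is built from compound 3 by one change: ethoxy in place of chloro on an aromatic carbon. Among the compounds with values here, none of the measured steps touches this position. All three measured steps exchange the whole group on the shared core, whereas the change to compound 4 alters only a substituent on the 4-chlorophenyl ring while the (4-chlorophenyl)amino attachment itself is kept. The measured steps therefore give no direct guide, and the most cautious expectation is a step that does not clearly exceed the scatter.

On that basis the expected step is a 1.1-fold higher number from compound 3 to compound 4 (0.05 log units; within the scatter), and compound 4 is estimated at 8000 nM, with a range from 2500 nM to 25000 nM.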

Compound 4, half-maximal inhibitory concentration: 32100 nM
The estimate for compound 4 lay 4.0-fold (0.60 log units) below the measured number, outside the stated range (above it).
By their numbers in this assay, from the lowest: compound 3; then compounds 1, 2 and 4 (each within the scatter of the next).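

In this assay, within the data shown here, the ring substituent turns out to matter, a point the earlier steps could not show because they all exchanged the whole group on the shared core: ethoxy in place of chloro, on an aromatic carbon para to a large group, gives a step beyond the scatter (a 4.5-fold higher number from compound 3 to compound 4 (0.65 log units; beyond the scatter)). The low number of compound 3 therefore does not come from having a substituted phenyl ring on that nitrogen alone, since the new steps to compound 4 from the piperidin-1-yl compound (a 1.3-fold higher number from compound 2 to compound 4 (0.10 log units; within the scatter)) and from the hexylamino compound (a 1.7-fold higher number from compound 1 to compound 4 (0.23 log units; within the scatter)) both lie within the scatter, leaving compound 4 not separable from either. Among the compounds shown, only the 4-chlorophenyl group stands apart, and no measurement here accounts for the size of this step.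

Still open, going by these compounds, is whether the change in the number follows from losing the chlorine or from gaining the ethoxy group. A methoxy group, a fluorine, a nitrile or a plain hydrogen at this position could help separate those two readings, and a longer chain on the oxygen would show whether the number keeps moving as the group grows.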